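Hydroxyphenyl Replacement on a Chalcone Growth Inhibitor

This account rests on a few compounds, and the source may have more. Where it says the series, first, only, none or still open, it means among the compounds named here.

Measured compounds:
compound 1, `COc1cc(/C=C/C(=O)c2cccc(-n3cc(-c4ccc(Cl)cc4)[nH]c3=O)c2)cc(OC)c1OC`: 3440 nM
compound 2, `COc1cc(/C=C/C(=O)c2cccc(-n3cc(-c4ccccc4)[nH]c3=O)c2)ccc1O`: 3650 nM

In a functional assay on SK-MEL-2 cells (Homo sapiens) for inhibition (on this read-out higher numbers stand for weaker inhibition of growth and lower numbers for stronger inhibition of growth), compound 1 gives 3440 nM, and compound 2 gives 3650 nM. Compound 2 stands beside compound 1; the two numbers sit within the scatter of each other, so no order between them can be read. Compound 3, `O=C(/C=C/c1cccc(O)c1)c1cccc(-n2cc(-c3ccccc3)[nH]c2=O)c1`, has not been measured in this assay. It differs from compound 2 in one place: 3-hydroxyphenyl in place of 4-hydroxy-3-methoxyphenyl on a double-bonded chain carbon bound to a double-bonded chain carbon. Going by the values given here, no pair of measured compounds shows a step of this kind, so there is no measured step to lean on. Among the compounds with values here, the only comparison at hand, compound 1 against compound 2, shows that a change on the same ring leaves the number within the scatter. Compound 3 is therefore expected to sit close to compound 2, with a step from compound 2 to compound 3 of a 1.1-fold higher number from compound 2 to compound 3 (0.04 log units; within the scatter), not beyond the scatter. The estimate for compound 3 is 4000 nM, with a range from 1500 nM to 11000 nM.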

Compound 3, concentration for 50% growth inhibition: 8260 nM
Beside the measured number, compound 3's estimate is 2.1-fold (0.31 log units) below it; the range from low to high includes it.
By their numbers in this assay, from the lowest: compounds 1 and 2 (each within the scatter of the next); then compound 3.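

In this assay, replacing 4-hydroxy-3-methoxyphenyl with 3-hydroxyphenyl on a double-bonded chain carbon bound to a double-bonded chain carbon gives a 2.3-fold higher number from compound 2 to compound 3 (0.35 log units; beyond the scatter), which means weaker inhibition of growth and shows that the number responds to a change at this position. This single change removes the methoxy group and also moves the hydroxyl, so the step cannot be assigned to either alteration alone. Nothing measured here explains the loss.

The compounds shown leave open how much of the step belongs to each alteration, which a 4-hydroxyphenyl or 3-methoxyphenyl group at this position could separate. They also leave open how an amine or a carboxylic acid on this ring would read in this assay.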